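The source may hold more compounds than are shown below. What is called first, only, known or untested is meant among the compounds shown, and "the series" means these compounds.

Three compounds of a shared core have been examined in a functional assay on the whole organism (strain albino) for inhibition, with Rattus norvegicus as the target, read by paw edema, with a stated time of 180 min, at a dose of 100 mg/kg by the oral route; a lower number here means less inhibition, a higher number more inhibition at the dose given (going by the name of the read-out). Compound 1 `COc1ccc(NCc2nc3ccccc3[nH]2)cc1` gives 33.3% in this assay. Compound 2 `Cc1ccc(NCc2nc3ccc(Br)cc3[nH]2)cc1` gives 16.6% in this assay, and compound 3 `O=[N+]([O-])c1ccc2nc(CNc3ccc(Br)cc3)[nH]c2c1` gives 22.2% in this assay. Compound 2 therefore stands lowest of the three numbers; its nearest neighbour is compound 3, whose number lies within the usual scatter of it, while the number of compound 1 lies beyond the scatter above it. No two of these measured compounds differ in only one place, so no single structural step can be read from the measured set.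

Compound 4 `Brc1ccc2nc(CNc3ccccc3)[nH]c2c1` has not yet been measured in this assay. It differs from compound 2 in one place: hydrogen in place of methyl on an aromatic carbon. Going by the values given here, since no measured pair shows what such a change does here, the data offer no direction for the step; the expectation is for a step that stays within the scatter, or only a little beyond it, in either direction. On that basis the number expected from compound 4 in this assay is 20%, with a range from 8% to 35%. That expected result corresponds to a step of a number 3.4 percentage points higher from compound 2 to compound 4 (within the scatter).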

Compound 4, a percentage reported as inhibition, in the whole organism at one dose (the size of the read-out at that dose, not a potency): 22.2%
The estimate for compound 4 lay 2.2 percentage points below the measured number; low and high end bracket the measured number.
By their numbers in this assay, from the lowest: compounds 2, 3 and 4 (each within the scatter of the next); then compound 1.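

In this assay, going by these compounds alone, the replacement of methyl by hydrogen gives the first step that can be read from a single structural change: a number 5.6 percentage points higher from compound 2 to compound 4 (within the scatter). At this aromatic carbon, para to a large group, the loss of the methyl group therefore does not separate the two compounds at the dose given, so the methyl group is not shown to be needed for the level of inhibition seen. No measurement bears on why the number holds across this change.

The compounds shown leave open whether a different group on the same aromatic carbon, such as an amine, a carboxylic acid or a longer alkyl chain, would give a step beyond the scatter, as this one comparison covers only hydrogen and methyl. They also leave open whether the change from methyl to hydrogen would give a similar step with the bromine on the shared core replaced by another group, or with the bromine absent.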